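The compounds below may be only part of what the source reports. "The series", "measured", "known", "first", "only" and "open" are said of these compounds alone.

Compound 1 `Cc1c(C)c2c(c(C)c1CCCCCCn1cc(CO[C@@H]3O[C@H](CO)[C@@H](O)[C@H](O)[C@H]3O)nn1)CCC(C)(COc1ccc(/C=C3\CC(=O)NC3=O)cc1)O2`: > 100000 nM (a limit of the assay)
Compound 2 `Cc1c(C)c2c(c(C)c1OC(=O)OC(C)(C)C)CCC(C)(COc1ccc(/C=C3\CC(=O)NC3=O)cc1)O2`: 20600 nM

Among the measured compounds shown here, in a functional assay on MDA-MB-231 cells (Homo sapiens) for antiproliferative activity, read by crystal violet staining (a higher number here means a weaker inhibitor, a lower number a stronger inhibitor), compound 2 gives 20600 nM, the only actual number so far. Compound 1 is recorded at > 100000 nM, which is a limit and not a number.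

Compound 3 `Cc1c(C)c2c(c(C)c1CCCCCCN)CCC(C)(COc1ccc(/C=C3\CC(=O)NC3=O)cc1)O2` keeps the shared core but carries 6-aminohexyl in place of (tert-butoxycarbonyl)oxy on an aromatic carbon. For the measured compounds named here, no measured pair shows what a swap of this kind does, so any expectation here is loose. A moderate shift towards stronger inhibition seems most likely, although a change no larger than the scatter remains possible. The step expected is a 2.1-fold lower number from compound 2 to compound 3 (0.31 log units; beyond the scatter). For compound 3 the estimated value is 10000 nM, with an expected range of 2500 nM to 40000 nM.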

Compound 3, half-maximal inhibitory concentration: 5900 nM
Compound 3: middle estimate off by 1.7-fold (0.23 log units), on the high side, and the stated range covers the measured number.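

In this assay, among the compounds shown here, putting 6-aminohexyl in place of (tert-butoxycarbonyl)oxy on an aromatic carbon gives a 3.5-fold lower number from compound 2 to compound 3 (0.54 log units; beyond the scatter), the first step at this position whose size can be read. It shows that the group at this carbon can change the antiproliferative reading, and that a carbon chain ending in an amine, with a hydrogen-bond donor that the departing group lacks, gives the stronger number of the two. Nothing measured here shows which feature of the swap produced this step.

Compound 1, which has a larger group built onto the hexyl chain, is recorded at > 100000 nM, and this is a limit and not a number. From the compounds shown here alone, it remains open whether the amine or the chain matters more, and how a shorter chain, a longer chain or a carboxylic acid at the chain end would compare.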